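This account rests on a few compounds, and the source may have more. Where it says the series, first, only, none or still open, it means among the compounds named here.

In an ADME assay on HEK293 cells (Homo sapiens) for cytotoxicity, read by resazurin assay, with a stated time of 48 h (a higher number here means that more compound is tolerated, a lower number that less compound is tolerated), three compounds with a shared core have been measured, and they differ only in the group on the sulfonyl sulfur. Compound 1 `Cc1ccc(S(=O)(=O)Nc2ccc(-c3nc4ccccc4o3)cc2)cc1` gives 88000 nM. Compound 2 `O=S(=O)(Nc1ccc(-c2nc3ccccc3o2)cc1)c1ccc(Cl)s1` reaches only a limit of the assay, > 100000 nM, so it has no exact number. Compound 3 `CCc1ccc(S(=O)(=O)Nc2ccc(-c3nc4ccccc4o3)cc2)cc1` gives 82000 nM, which stands level with compound 1 within the usual scatter.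

Compound 4 `COc1cccc(S(=O)(=O)Nc2ccc(-c3nc4ccccc4o3)cc2)c1` has 3-methoxyphenyl in place of 4-ethylphenyl on a sulfonyl sulfur. The measured steps at this same place are all small: a 1.1-fold lower number from compound 1 to compound 3 (0.03 log units; within the scatter), an at least 1.1-fold higher number from compound 1 to compound 2 (0.05 log units; that floor lies within the scatter) and an at least 1.2-fold lower number from compound 2 to compound 3 (0.08 log units; that floor lies within the scatter). The last two rest on a limit, so they show only a floor and not a true size. None of these steps involves 3-methoxyphenyl, which leaves some uncertainty. Even so, this assay is expected to show no change beyond the scatter, with an estimated 1.0-fold lower number from compound 3 to compound 4 (0.01 log units; within the scatter). The estimate for compound 4 is 80000 nM, with an expected range of 40000 nM to 100000 nM.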

Compound 4, half-maximal cytotoxic concentration: > 100000 nM
Compound 4 was reported as a limit; the forecaster's own chance of this, stated with the estimate: 25%; middle value at least 1.2-fold (0.09 log units) away from the limit.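

In this assay compound 4 is reported only as a limit of the assay, > 100000 nM, so 3-methoxyphenyl, the first group here with a hydrogen-bond acceptor, joins the groups on the sulfonyl sulfur with no step shown to lie beyond the scatter. Placing it on the sulfonyl sulfur gives an at least 1.2-fold higher number from compound 3 to compound 4 (0.08 log units; that floor lies within the scatter) and an at least 1.1-fold higher number from compound 1 to compound 4 (0.05 log units; that floor lies within the scatter), and both are floors, so the real steps could be larger. The step between compound 2 and compound 4 cannot be read, and these floors stay floors, because of where the values sit: the limit of > 100000 nM in this assay, at which 2 of the 4 values shown sit.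

Still open, going by these compounds, is whether any group on the sulfonyl sulfur can move the number beyond the scatter. An amine, a carboxylic acid or a longer chain in this place would test that.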